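The compounds below may be only part of what the source reports. "The series", "measured", "known", "first", "only" and "open" are said of these compounds alone.

Measured in a functional assay on SH-SY5Y cells (Homo sapiens) for antiproliferative activity, read by MTT assay, with a stated time of 48 h; on this read-out higher numbers stand for weaker inhibition of growth and lower numbers for stronger inhibition of growth:

Compound 1 `COc1ccc(N(C)c2ncnc3c2ncn3Cc2ccc(OC)c(OC)c2)cc1`: 430 nM
Compound 2 `COc1ccc(Cn2cnc3c(Cl)ncnc32)cc1`: > 50000 nM

Of these two compounds, only compound 1 has a true number. Compound 2 gives > 50000 nM, which is a limit of this assay and not a number. Its real value is therefore unknown, and it stands at the weak end of the range shown.

Compound 3 `COc1ccc(Cn2cnc3c(Cl)ncnc32)cc1OC` is built from compound 2 by one change: methoxy in place of hydrogen on an aromatic carbon, ortho to a methoxy group (methoxy in place of hydrogen on an aromatic carbon). Within the data shown here, no measured pair shows what such a change does in this assay, so the expectation rests on the starting point alone. The starting point for this step is compound 2 at > 50000 nM. A single added methoxy is expected to leave compound 3 close to that limit, with at most a small step towards stronger inhibition of growth, and the assay may again report only a limit. The expected change is an at least 1.2-fold lower number from compound 2 to compound 3 (0.09 log units; that floor lies within the scatter). For compound 3 the estimated value is 40000 nM, with an expected range from 15000 nM to 50000 nM.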

Compound 3, concentration for 50% growth inhibition: > 100000 nM
Compound 3: a limit, no number; the forecaster's own chance of this, stated with the estimate: 65%; middle value at least 2.5-fold (0.39 log units) from the limit.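

In this assay, the added methoxy, ortho to a methoxy group, does not bring compound 3 into the measurable range: like compound 2, it gives only a limit of the assay, so the step between these two compounds cannot be read. Compound 3 also differs from compound 1 in one place, with chloro in place of (4-methoxyphenyl)(methyl)amino on an aromatic carbon, and this change gives an at least 230-fold higher number from compound 1 to compound 3 (2.36 log units; beyond the scatter). In this pair, then, the two methoxy groups on the benzyl ring are not enough on their own for measurable growth inhibition, and the large step goes with the loss of the (4-methoxyphenyl)(methyl)amino group.

On these data alone, what the added methoxy does when the (4-methoxyphenyl)(methyl)amino group is present remains open, as do the true values behind the two limits. As far as these compounds go, it is also open how a smaller group in place of chloro, such as a plain amino group or dimethylamino, would behave, and so whether the aromatic ring of the large group is needed for growth inhibition.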